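A few compounds are considered here, and "the series" means these few. Any claim that something is new, unique, unknown or untested is made for them only; others in the source may bear on it.

Among the measured compounds shown here, in a functional assay on Right cardiac atrium for agonist activity at histamine H2 receptor (Cavia porcellus), with a stated time of 30 min, in the presence of a further agent that is not named here (on this read-out higher numbers stand for larger maximal responses and lower numbers for smaller maximal responses), compound 2 `Cc1nc(N)sc1CCCN/C(N)=N/C(=O)NC(C)c1ccco1` gives 1, and the only other measured compound, compound 1 `Cc1nc(N)sc1CCCN/C(N)=N/C(=O)NC(C)c1ccccc1F` with 0.93, lies within the scatter of it, as the step a number 0.070 higher from compound 1 to compound 2 (within the scatter) shows. Compound 3 `Cc1nc(N)sc1CCCN/C(N)=N/C(=O)NC(C)c1cccc(F)c1` differs from compound 2 by 3-fluorophenyl in place of furan-2-yl on a saturated chain carbon bound to an amide-type nitrogen and a saturated chain carbon. For the measured compounds named here, the one measured step, a number 0.070 higher from compound 1 to compound 2 (within the scatter), concerns the same place and swapped one aromatic group for another without a change beyond the scatter, so no movement beyond the scatter is expected here either, a number 0.050 lower from compound 2 to compound 3 (within the scatter). Compound 3 is therefore estimated at 0.95, between 0.85 and 1.05.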

Compound 3, intrinsic activity: the largest response reached, as a fraction of the reference agonist's: 0.85
The estimate for compound 3 lay 0.10 above the measured number; measured number inside the range.
By their numbers in this assay, from the lowest: compounds 3, 1 and 2 (each within the scatter of the next, the first and the last beyond it).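

At the saturated chain carbon bound to an amide-type nitrogen and a saturated chain carbon, the swap of one aromatic group for another now gives a step beyond the scatter in this assay: a number 0.15 lower from compound 2 to compound 3 (beyond the scatter). That step is modest, and the exchange of 2-fluorophenyl for 3-fluorophenyl stays within the scatter, with a number 0.080 lower from compound 1 to compound 3 (within the scatter), so the two fluorophenyl compounds cannot be told apart. Nothing available accounts for the step. The compounds shown leave open how the response changes with a simple amine or a carboxylic acid at this place, since every group seen here is aromatic.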